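This account rests on a few compounds, and the source may have more. Where it says the series, first, only, none or still open, it means among the compounds named here.

Measured compounds:
- compound 1, `Cn1sc2cc(OCc3cccc(-c4ccc(Cl)c(C(=O)O)c4)c3)ccc2c1=O`: 74.7%
- compound 3, `O=C(O)c1cc(-c2cccc(-c3ccc4c(c3)CN(C3CCCC3)C4=O)c2)ccc1Cl`: 85.8%
- compound 2, `O=C1c2ccc(OCc3cccc(-c4ccc(C(F)(F)F)cc4F)c3)cc2CN1C1CCCC1`: "not determined" (no result reported)

Two compounds carry a number in an assay on HEK293 cells for positive allosteric modulation of metabotropic glutamate receptor 2 (Rattus norvegicus), read by thallium flux; a lower number here means a smaller maximal response, a higher number a larger maximal response. Compound 1 gives 74.7%, the lower of the two. Compound 3 gives 85.8%, and the gap between the two is beyond the usual scatter, though these two compounds differ in more than one place, so their values can only be compared as they stand. Compound 2 has no result in this assay.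

Compound 4, `CC(C)Cn1sc2cc(OCc3cccc(-c4ccc(Cl)c(C(=O)O)c4)c3)ccc2c1=O`, differs from compound 1 in one place: isopropyl in place of hydrogen on a saturated chain carbon bound to an aromatic nitrogen. A more extensive branch is thereby attached where compound 1 carries only hydrogen; read one bond further out, the change is methyl to isobutyl.

Within the data shown here, no single step between measured compounds shows what such a change does. In this assay, the step from compound 1 to compound 4 is expected to be small, probably upward, and may well lie within the scatter: a number 5.3 percentage points higher from compound 1 to compound 4 (within the scatter). Compound 4 is therefore expected to give about 80%, somewhere between 62% and 98%.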

Compound 4, largest response reached (reported as percent of maximum), in percent of the reference or control that the assay uses: 76.2%
For compound 4 the middle estimate is 3.8 percentage points above the measured one; the measured number falls inside the stated range.
By their numbers in this assay, from the lowest: compounds 1, 4 and 3 (each within the scatter of the next, the first and the last beyond it).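

In this assay the new step reads a number 1.5 percentage points higher from compound 1 to compound 4 (within the scatter). At this position, on a saturated chain carbon bound to an aromatic nitrogen, methyl can therefore be exchanged for the branched isobutyl, a change of 3 heavy atoms with no ring, without a maximal response that can be told apart from that of compound 1. None of the data shown gives a reason for this outcome.

Only these two groups are shown at this position, so the response with a chain of another shape, such as straight hexyl, remains open. Going by these compounds, it is equally open whether a chain ending in an amine or a phenyl ring would leave the maximal response just as unchanged.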